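Methyl in place of bromo on the aryl ring

The source may report more compounds than this note shows. Statements on the series, on what has been measured and on what is new or still open speak of the compounds shown alone.

Compound 1, `CC1=C(/C=C/C(=O)/C=C/c2ccc(Cl)cc2)C(C)(C)CCC1`: 33200 nM
Compound 2, `CC1=C(/C=C/C(=O)/C=C/c2ccccc2Br)C(C)(C)CCC1`: 57900 nM

Both compounds were tested in a functional assay on HeLa cells (Homo sapiens) for cytotoxicity, read by sulforhodamine B assay, with a stated time of 48 h; a higher number here means a weaker inhibitor, a lower number a stronger inhibitor. Compound 2 carries the higher of the two numbers, yet the step of a 1.7-fold higher number from compound 1 to compound 2 (0.24 log units; within the scatter) lies within the scatter, so the two cannot be told apart on these data.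

Compound 3, `CC1=C(/C=C/C(=O)/C=C/c2ccccc2C)C(C)(C)CCC1`, differs from compound 2 by a single exchange: methyl in place of bromo on an aromatic carbon. Within the data shown here, only one measured step touches the same ring, a 1.7-fold higher number from compound 1 to compound 2 (0.24 log units; within the scatter), and it replaces one halogen by another at a different position rather than a halogen by a methyl; it stayed within the scatter. Among the measured compounds shown here, no measured step exchanges bromo for methyl anywhere. Compound 3 is therefore expected to move by a 1.2-fold lower number from compound 2 to compound 3 (0.06 log units; within the scatter) in this assay, a change not beyond the scatter. The estimate for compound 3 is 50000 nM, within a range from 20000 nM to 125000 nM.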

Compound 3, half-maximal inhibitory concentration: > 100000 nM
Compound 3 ended at the assay's limit; the forecaster's own chance of this, stated with the estimate: 15%; middle value at least 2.0-fold (0.30 log units) from the limit.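

Compound 3 stands at a limit of the assay, not at a number: the limit of > 100000 nM in this assay, at which 1 of the 3 values shown sits. As far as these compounds go, the exchange of bromo for methyl on this aromatic carbon, ortho to a large group, gives an at least 1.7-fold higher number from compound 2 to compound 3 (0.23 log units; that floor lies within the scatter), so the floor alone does not separate the two compounds and the true size of the step remains unknown. Against the 4-chlorophenyl group, however, 2-methylphenyl gives an at least 3.0-fold higher number from compound 1 to compound 3 (0.47 log units; beyond the scatter), a separation that the two halogen-bearing compounds did not show between them.

The compounds shown leave open whether the group or its place on the ring carries that step, for 4-chlorophenyl and 2-methylphenyl differ in both. They also leave open how an amine or a carboxylic acid on this aromatic carbon would read in this assay.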